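Chloro Added at a New Place on a Potent Core

A few compounds are considered here, and "the series" means these few. Any claim that something is new, unique, unknown or untested is made for them only; others in the source may bear on it.

Three compounds have so far been examined in an assay on IM-9 cells for binding affinity to Substance-P receptor (Homo sapiens); on this read-out lower numbers stand for stronger inhibition and higher numbers for weaker inhibition. Compound 1, `CN(Cc1cc(C(F)(F)F)cc(C(F)(F)F)c1)C(=O)c1c(-c2ccccc2)c2ccccc2c(=O)n1C`, gives 1.2 nM in this assay. Compound 2, `Cc1cc2c(-c3ccccc3)c(NC(=O)N(C)Cc3ccccc3)n(C)c(=O)c2cc1C`, gives 16 nM. Compound 3, `Cc1cc2c(-c3ccccc3)c(NC(=O)N(C)Cc3ccccc3Cl)n(C)c(=O)c2cc1C`, gives 4.2 nM. Compounds 2 and 3 differ in one place: chloro in place of hydrogen on an aromatic carbon. That change brought a 3.8-fold lower number from compound 2 to compound 3 (0.58 log units; beyond the scatter). How the core of compound 1 differs from the core of compound 2 is not broken down here; the two differ in more than one place, and their values show compound 1 giving the lower number of the two.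

The next compound, compound 4, `CN(Cc1cc(C(F)(F)F)cc(C(F)(F)F)c1)C(=O)c1c(-c2ccccc2)c2cc(Cl)ccc2c(=O)n1C`, has not yet been measured. It differs from compound 1 in one place: chloro in place of hydrogen on an aromatic carbon. Among the compounds with values here, this is the same kind of change as the one between compounds 2 and 3, but not the same. In compounds 2 and 3 the chloro sits on a six-membered aromatic ring of carbon only, ortho to a large group, so that phenyl becomes 2-chlorophenyl; in compound 4 it sits on a ring that is part of a fused or bridged system of two rings, meta to a fused ring and para to a fused ring.

The step from compound 1 to compound 4 is expected to be a 1.3-fold lower number from compound 1 to compound 4 (0.12 log units; within the scatter). This rests on a 3.8-fold lower number from compound 2 to compound 3 (0.58 log units; beyond the scatter), a change of the same kind at a different place, and on the fact that compound 1 already gives 1.2 nM, the lowest of the three numbers. Compound 4 is therefore expected to give about 0.9 nM in this assay, with a likely range from 0.3 nM to 3 nM.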

Compound 4, half-maximal inhibitory concentration: 3.4 nM
Estimate against measurement, compound 4: 3.8-fold (0.58 log units) below, and the stated range ends below it.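

In this assay, putting chloro in place of hydrogen on an aromatic carbon of the fused ring system of compound 1 gave a 2.8-fold higher number from compound 1 to compound 4 (0.45 log units; beyond the scatter), so on this core the change went with weaker inhibition rather than stronger. Set beside the earlier step, the same kind of change moved the number in opposite directions, which shows that its effect on one core cannot simply be carried over to the other in this series: the same change on two cores in this assay, a 3.8-fold lower number (0.58 log units; beyond the scatter) from compound 2 to compound 3 and a 2.8-fold higher number (0.45 log units; beyond the scatter) from compound 1 to compound 4, 11-fold (1.03 log units) apart, beyond the scatter of two such steps. This does not show why the two steps part ways, since the chloro of compound 3 sits on a phenyl ring and that of compound 4 on a ring of a fused system, and the cores differ as well, so two steps cannot separate the place of the chloro from the core that carries it.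

The compounds shown leave open whether a fluoro or a methoxy group at the place used in compound 4 would raise the number as chloro does. They also leave open how chloro would behave on the core of compound 1 at other aromatic carbons, including those of its phenyl ring, which would help to show how much the place matters on that core.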